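A few compounds are considered here, and "the series" means these few. Any claim that something is new, unique, unknown or untested is made for them only; others in the source may bear on it.

The measured compounds:
Compound 1 `Cc1c(O[C@@H](C)COc2ccc(F)c(C(=O)O)c2)ccc(C(=O)CC(C)(C)C)c1O`; in an assay for positive allosteric modulation of metabotropic glutamate receptor 2 (Rattus norvegicus) (a lower number here means that less compound is needed, a higher number that more compound is needed for the effect), compound 1 gives 257 nM.
Compound 2 `Cc1c(OC[C@H](C)COc2ccc(F)c(C(=O)O)c2)ccc(C(=O)CC(C)(C)C)c1O`; compound 2 gives 294 nM.
Compound 3 `Cc1c(OC[C@@H](C)COc2ccc(F)c(C(=O)O)c2)ccc(C(=O)CC(C)(C)C)c1O`; compound 3 gives 112 nM.

Compound 3 stands lowest of the three numbers. Compound 1 is nearest to it and compound 2 furthest, and both gaps lie beyond the scatter. Going by the values given here, only one step between compounds differing in a single place is available: a 2.6-fold lower number from compound 2 to compound 3 (0.42 log units; beyond the scatter), a change that rests on (the fact that compounds 2 and 3 differ only in the configuration as drawn).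

Compound 4 `Cc1c(OC[C@@H](C)COc2ccc(C(=O)O)c(F)c2)ccc(C(=O)CC(C)(C)C)c1O` differs from compound 3 in 4-carboxy-3-fluorophenyl in place of 3-carboxy-4-fluorophenyl on an oxygen on a saturated carbon. Among the compounds with values here, no measured pair shows this kind of change. Within the data shown here, the single step seen concerns configuration at a chain carbon and not the arrangement of the carboxylic acid and fluorine on the aromatic ring, so it does not bear directly on the step to compound 4. Compound 1 and compound 3 differ in more than one respect, so their two values alone give no clean guide either. With nothing to anchor it, the step of a 1.8-fold higher number from compound 3 to compound 4 (0.25 log units; within the scatter) is expected to be small, within or near the scatter, and its direction is uncertain. Compound 4 is therefore estimated at 200 nM, with a range from 60 nM to 700 nM.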

Compound 4, half-maximal effective concentration: 261 nM
Estimate against measurement, compound 4: 1.3-fold (0.12 log units) below; the measured number falls inside the stated range.
By their numbers in this assay, from the lowest: compound 3; then compounds 1, 4 and 2 (each within the scatter of the next).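

The exchange of 3-carboxy-4-fluorophenyl for 4-carboxy-3-fluorophenyl on an oxygen on a saturated carbon gives, in this assay, a 2.3-fold higher number from compound 3 to compound 4 (0.37 log units; beyond the scatter). The two groups have the same atoms and the same counts, so the number here moves with the way the atoms are joined on the ring alone. Before this, the only single-place step concerned configuration at a chain carbon, so this is the first sign that the aromatic ring at this position also affects the number, and nothing at hand accounts for the size or direction of this step.

The compounds shown leave open whether the change in the number follows the carboxylic acid or the fluorine, since a ring bearing only the carboxylic acid, or one with chlorine or a methoxy group in place of the fluorine, is not among them. They also leave open whether the same exchange would have a similar effect with the opposite configuration at the chain carbon or with the chain of compound 1.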